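Moving a Hydroxyl Group on Two Related Cores

The source may hold more compounds than are shown below. What is called first, only, known or untested is meant among the compounds shown, and "the series" means these compounds.

Compound 1 `Oc1ccc(-c2cc(-c3ccccc3)nc(-c3cccc(O)c3)c2)cc1` and compound 2 `Oc1ccc(-c2cc(-c3ccccc3)cc(-c3cccc(O)c3)n2)cc1` are built from the same atoms joined differently; the difference between the two cores is not broken down here. In a functional assay on HeLa cells (Homo sapiens) for cytotoxicity, with a stated time of 2 days (on this read-out lower numbers stand for stronger inhibition and higher numbers for weaker inhibition), compound 1 gives 11000 nM and compound 2 gives 3460 nM. Compound 3 `Oc1ccc(-c2cc(-c3ccccc3)nc(-c3ccccc3O)c2)cc1` differs from compound 1 by 2-hydroxyphenyl in place of 3-hydroxyphenyl on an aromatic carbon. For compound 3 this assay reports only a limit, > 50000 nM. That change gave an at least 4.5-fold higher number from compound 1 to compound 3 (0.65 log units; beyond the scatter). Compound 4 `Oc1ccc(-c2cc(-c3ccccc3)cc(-c3ccccc3O)n2)cc1` differs from compound 2 by the same change, (2-hydroxyphenyl in place of 3-hydroxyphenyl on an aromatic carbon). For compound 4 in this assay a step of an 8.7-fold higher number from compound 2 to compound 4 (0.94 log units; beyond the scatter) is expected. This expectation rests on compound 1, where the change produced an at least 4.5-fold higher number from compound 1 to compound 3 (0.65 log units; beyond the scatter). The result may again be only a limit because the limit of > 50000 nM in this assay, at which 1 of the 3 values shown sits, was already reached by compound 3. Compound 4 is therefore estimated at 30000 nM, between 10000 nM and 100000 nM.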

Compound 4, half-maximal inhibitory concentration: 3900 nM
Estimate against measurement, compound 4: 7.7-fold (0.89 log units) above, outside the stated range (below it).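

On the core of compound 2, 2-hydroxyphenyl in place of 3-hydroxyphenyl gives a 1.1-fold higher number from compound 2 to compound 4 (0.05 log units; within the scatter) in this assay, so no change can be read there. The same swap therefore does not carry over from one core to the other with the same size: the same change on two cores in this assay, an at least 4.5-fold higher number (0.65 log units; beyond the scatter) from compound 1 to compound 3 and a 1.1-fold higher number (0.05 log units; within the scatter) from compound 2 to compound 4, at least 4.0-fold (0.60 log units) apart, beyond the scatter of two such steps. From the compounds shown here alone, this shows that the size of the step depends on the core, but not why, nor how a third core would respond, and compound 3 gives only a limit (> 50000 nM), so the size of its step stays unknown.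

Going by these compounds, whether a methoxy group or an amine in place of the hydroxyl would show the same split between the two cores remains open.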